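A few compounds are considered here, and "the series" means these few. Any claim that something is new, unique, unknown or untested is made for them only; others in the source may bear on it.

For the measured compounds named here, in a functional assay on PC-3 cells (Homo sapiens) for antiproliferative activity, read by MTT assay, with a stated time of 72 h (a lower number here means a stronger inhibitor, a higher number a weaker inhibitor), compound 1 (`CCn1cc(C(CC)(CC)c2ccc(C#CC(O)(CC)CC)c(C)c2)cc1C(=O)NCC(=O)OC`) gives 17500 nM and compound 2 (`CCn1cc(C(CC)(CC)c2ccc(C#CC(O)(CC)CC)c(C)c2)cc1C(=O)NCC(=O)O`) gives 6300 nM as the lower of the two numbers so far. Compound 3 (`CCn1cc(C(CC)(CC)c2ccc(C#CC(O)(CC)CC)c(C)c2)cc1C(=O)NCCC(=O)O`) departs from compound 2 in one place: carboxymethyl in place of carboxy on a saturated chain carbon bound to an amide-type nitrogen with carboxymethyl in place of carboxy on a saturated chain carbon bound to an amide-type nitrogen. The same difference reads as (carboxymethyl)carbamoyl to (2-carboxyethyl)carbamoyl. Going by the values given here, the only measured step that bears on this is a 2.8-fold lower number from compound 1 to compound 2 (0.44 log units; beyond the scatter) and it concerns the methyl on the oxygen, not the length of the chain. Among the compounds with values here, no measured step lengthens this chain, so its size cannot be carried over and the direction stays open. The expected change is a 1.1-fold higher number from compound 2 to compound 3 (0.05 log units; within the scatter) and this is estimated to stay within the scatter. For compound 3 the estimate in this assay is 7000 nM with an expected range from 2800 nM to 18000 nM around it.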

Compound 3, half-maximal inhibitory concentration: > 50000 nM
Compound 3 was reported as a limit (the forecaster's own chance of this, stated with the estimate: 10%); middle value at least 7.1-fold (0.85 log units) away from the limit.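

In this assay, the side chain on the amide-type nitrogen proves sensitive to its length: one added chain carbon, carboxymethyl becoming 2-carboxyethyl, gives an at least 7.9-fold higher number from compound 2 to compound 3 (0.89 log units; beyond the scatter). For the compounds shown here, this is the first step here that touches the chain itself rather than the methyl on the oxygen, and it shows that a free carboxylic acid alone does not secure the lower number, since the longer acid also falls behind the methyl ester, with an at least 2.8-fold higher number from compound 1 to compound 3 (0.45 log units; beyond the scatter). Compound 3 stands at a limit, not at a number: the limit of > 50000 nM in this assay, at which 1 of the 3 values shown sits.

From the compounds shown here alone, how large the loss really is therefore stays open. Also open, going by these compounds, is whether a methyl ester on the 2-carboxyethyl chain, a still longer chain, or an amine at the chain end would recover any activity.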